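Swapping the lactone of compound 1 for a pyrrolidinone

The source may report more compounds than this note shows. Statements on the series, on what has been measured and on what is new or still open speak of the compounds shown alone.

Measured so far:
compound 1, `C[C@]1(O)CC(=O)OC(CSc2nc(-c3ccccc3)c(-c3ccccc3)[nH]2)C1`: 140 nM
compound 2, `CC(O)(CC(=O)OC(C)(C)C)CC(O)CSc1nc(-c2ccc(Cl)cc2)c(-c2ccc(Cl)cc2)[nH]1`: 250 nM

Both compounds were tested in an assay on microsomes from liver for inhibition of sterol O-acyltransferase 1 (Rattus norvegicus); on this read-out lower numbers stand for stronger inhibition and higher numbers for weaker inhibition. Compound 1 gives 140 nM, the lowest of the two numbers, while compound 2 gives 250 nM; the gap between them is within the scatter, so neither can be called the stronger inhibitor.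

Compound 3, `O=C1CCC(CSc2nc(-c3ccccc3)c(-c3ccccc3)[nH]2)N1`, has not yet been measured. It differs from compound 1 in one place: a group of 6 heavy atoms (4 carbon, 1 nitrogen, 1 oxygen; one five-membered non-aromatic ring with 1 hetero atom) in place of a group of 9 heavy atoms (6 carbon, 3 oxygen; one six-membered non-aromatic ring with 1 hetero atom), on a saturated chain carbon bound to a sulfur. Within the data shown here, no step between two measured compounds follows this change, so its size in this assay is unknown. The change replaces a ring with a group that keeps one hydrogen-bond donor while the count of acceptors falls, and a step of modest size in either direction, or none beyond the scatter, seems plausible.

For compound 3 the expected number in this assay is 300 nM, with a range from 80 nM to 1200 nM. This estimate means a step from compound 1 to compound 3 of a 2.1-fold higher number from compound 1 to compound 3 (0.33 log units; beyond the scatter), expected toward weaker inhibition, but only slightly.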

Compound 3, half-maximal inhibitory concentration: 360 nM
Estimate against measurement, compound 3: 1.2-fold (0.08 log units) below, and the stated range covers the measured number.
By their numbers in this assay, from the lowest: compounds 1, 2 and 3 (each within the scatter of the next, the first and the last beyond it).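

Among these compounds, putting 5-oxopyrrolidin-2-yl in place of the lactone, on a saturated chain carbon bound to a sulfur, gives a 2.6-fold higher number from compound 1 to compound 3 (0.41 log units; beyond the scatter) in this assay, the first step at this position. The lactone is therefore not required for inhibition here, although the smaller group that enters, with fewer heavy atoms and hydrogen-bond acceptors, gives weaker inhibition by a modest margin. No measurement available here accounts for the size of this step.

The compounds shown leave open how a six-membered lactam or an open-chain carboxylic acid would read at this place. They also do not separate ring size from ring atoms, since both differ together in this single step.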